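Swapping the phenyl of compound 2 for an isopropyl group

The source may report more compounds than this note shows. Statements on the series, on what has been measured and on what is new or still open speak of the compounds shown alone.

Compound 1, `CC/C(=C\C=C\C(=O)N[C@H](C)CCCc1cccnc1)c1ccc(OC)cc1`, in a functional assay with platelet-activating factor receptor (Cavia porcellus) as the target (a higher number here means that more compound is needed for the effect, a lower number that less compound is needed), gives 0.68 mg/kg.
Compound 2, `COc1ccc(/C(=C/C=C/C(=O)N[C@H](C)CCCc2cccnc2)c2ccccc2)cc1`, in this assay gives 0.16 mg/kg.

Compound 2 has the lower of the two numbers: a 4.3-fold lower number from compound 1 to compound 2 (0.63 log units; beyond the scatter), a change that is more than the usual scatter, and it came with phenyl in place of ethyl on the double-bonded chain carbon. Compound 3, `COc1ccc(/C(=C/C=C/C(=O)N[C@H](C)CCCc2cccnc2)C(C)C)cc1`, is the next step from compound 2: isopropyl in place of phenyl on a double-bonded chain carbon bound to an aromatic carbon and a double-bonded chain carbon. Within the data shown here, this is the reverse kind of change to the only step measured so far, since the phenyl that lowered the number from compound 1 to compound 2 is now replaced by a branched alkyl group of similar size to the ethyl of compound 1. For compound 3 a rise in the number back toward compound 1 is therefore expected, roughly a 3.1-fold higher number from compound 2 to compound 3 (0.49 log units; beyond the scatter). Compound 3 is estimated at 0.5 mg/kg, with a likely range of 0.2 mg/kg to 1.4 mg/kg.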

Compound 3, dose for 50% inhibition: 0.41 mg/kg
Beside the measured number, compound 3's estimate is 1.2-fold (0.09 log units) above it, and the stated range covers the measured number.
By their numbers in this assay, from the lowest: compound 2; then compounds 3 and 1 (each within the scatter of the next).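

Phenyl on this double-bonded chain carbon now stands apart from two different alkyl groups, not only from ethyl: in this assay, replacing it with isopropyl gives a 2.6-fold higher number from compound 2 to compound 3 (0.41 log units; beyond the scatter). Ethyl and isopropyl, by contrast, cannot be told apart at this position, with a 1.7-fold lower number from compound 1 to compound 3 (0.22 log units; within the scatter), so the added methyl makes no readable difference here. No measurement available here explains why phenyl gives the lower number.

The compounds shown leave open whether this result needs an aromatic ring at all, a question that a cyclohexyl group in the same place could help to settle. As far as these compounds go, it also remains open how a pyridyl ring, a substituted phenyl such as 4-fluorophenyl, or a longer chain such as n-butyl would compare.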